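Shifting the methoxy group along the benzyl ether

This account rests on a few compounds, and the source may have more. Where it says the series, first, only, none or still open, it means among the compounds named here.

Compound 1 `O=c1cc(Cn2ccnc2)c2ccc(OCc3cccc(Cl)c3)cc2o1`: 101 nM
Compound 2 `COc1ccc(COc2ccc3c(Cn4ccnc4)cc(=O)oc3c2)cc1OC`: 82 nM
Compound 3 `COc1ccc(COc2ccc3c(Cn4ccnc4)cc(=O)oc3c2)cc1`: 124 nM

In an assay on V79MZh11B2 cells for inhibition of cytochrome P450 11B2, mitochondrial (Homo sapiens), read by HPLC, with a stated time of 25 min (on this read-out lower numbers stand for stronger inhibition and higher numbers for weaker inhibition), compound 3 stands alongside compound 1 and compound 2, since a 1.2-fold higher number from compound 1 to compound 3 (0.09 log units; within the scatter) and a 1.5-fold higher number from compound 2 to compound 3 (0.18 log units; within the scatter) both lie within the scatter. Compound 4 `COc1cccc(COc2ccc3c(Cn4ccnc4)cc(=O)oc3c2)c1` carries the change (3-methoxyphenyl in place of 4-methoxyphenyl on a saturated chain carbon bound to an oxygen on an aromatic ring). For the measured compounds named here, two measured steps bear on it: the change of the aryl group at the same place, a 1.2-fold higher number from compound 1 to compound 3 (0.09 log units; within the scatter), and the loss of a methoxy group, a 1.5-fold higher number from compound 2 to compound 3 (0.18 log units; within the scatter), and neither moved the number beyond the scatter. A step of the same kind is therefore expected from compound 3 to compound 4, a 1.0-fold lower number from compound 3 to compound 4 (0.01 log units; within the scatter), with no clear direction. Compound 4 is estimated at 120 nM, within 50 nM to 300 nM.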

Compound 4, half-maximal inhibitory concentration: 127 nM
Compound 4: the middle estimate sits 1.1-fold (0.02 log units) below what was measured; the measured number falls inside the stated range.
By their numbers in this assay, from the lowest: compounds 2, 1, 3 and 4 (each within the scatter of the next).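

The 4-methoxyphenyl and 3-methoxyphenyl groups cannot be told apart at this place in this assay (a 1.0-fold higher number from compound 3 to compound 4 (0.01 log units; within the scatter)). Compound 4 also stays within the scatter of both other compounds, for hydrogen in place of methoxy (a 1.5-fold higher number from compound 2 to compound 4 (0.19 log units; within the scatter)) and for methoxy in place of chloro (a 1.3-fold higher number from compound 1 to compound 4 (0.10 log units; within the scatter)). Among these four compounds, neither the position of the methoxy group nor the exchanges tested here separates one compound from another.

From the compounds shown here alone, whether an amine or a carboxylic acid on this aromatic ring, or a longer chain at this place, would move the number beyond the scatter remains open. Nothing available explains why these compounds read alike.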